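Trading an Ester Chain for a Bromophenyl Ring

This account rests on a few compounds, and the source may have more. Where it says the series, first, only, none or still open, it means among the compounds named here.

Among the compounds with values here, compound 2 `CCOC(=O)CCSc1nc2ccccc2n1CC(=O)O` gives 11400 nM in an assay on HEK293 cells for displacement of a labelled ligand from prostaglandin D2 receptor 2 (Homo sapiens) (a higher number here means a weaker inhibitor, a lower number a stronger inhibitor), the highest of the two numbers measured so far; its nearest neighbour, compound 1 `O=C(O)Cn1c(SCCNc2ccccc2)nc2ccccc21`, gives 7690 nM. Within the data shown here, the only known step, a 1.5-fold higher number from compound 1 to compound 2 (0.17 log units; within the scatter), altered a group two bonds along the chain from a sulfur and stayed within the scatter. Compound 3 `O=C(O)Cn1c(SCc2ccccc2Br)nc2ccccc21` differs from compound 2 by 2-bromophenyl in place of (ethoxycarbonyl)methyl on a saturated chain carbon bound to a sulfur. Among the measured compounds shown here, no measured step exchanges a chain for an aromatic ring at this place, so guidance is thin. A modest drop in the number is expected, a 2.9-fold lower number from compound 2 to compound 3 (0.45 log units; beyond the scatter). Compound 3 is therefore estimated at 4000 nM, with a range from 1000 nM to 16000 nM.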

Compound 3, half-maximal inhibitory concentration: 580 nM
The estimate for compound 3 lay 6.9-fold (0.84 log units) above the measured number; the whole stated range lies above it.
By their numbers in this assay, from the lowest: compound 3; then compounds 1 and 2 (each within the scatter of the next).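

In this assay, putting 2-bromophenyl in place of (ethoxycarbonyl)methyl on a saturated chain carbon bound to a sulfur gives a 20-fold lower number from compound 2 to compound 3 (1.29 log units; beyond the scatter). The earlier change at this part of the chain, a 1.5-fold higher number from compound 1 to compound 2 (0.17 log units; within the scatter), gave no sign that the number could move this far. No available evidence explains the size of this drop.

Whether the aromatic ring or the bromine accounts for the change remains open, since the two enter together. A plain phenyl ring, or a chlorine in place of the bromine, would help separate them.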